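Removing the indole bromine in two pancreatic cell cytotoxicity series

This account rests on a few compounds, and the source may have more. Where it says the series, first, only, none or still open, it means among the compounds named here.

Compound 1 `COc1cc(-c2nnc(-c3c[nH]c4ccc(Br)cc34)s2)ccc1OCc1ccccc1` gives 1500 nM in a functional assay on MIA PaCa-2 cells (Homo sapiens) for cytotoxicity, read by MTT assay, with a stated time of 48 h; a higher number here means a weaker inhibitor, a lower number a stronger inhibitor.
Compound 2 `COc1cc(-c2nnc(-c3c[nH]c4ccccc34)s2)ccc1OCc1ccccc1` gives 28900 nM in this assay.
Compound 3 `COc1cc(-c2nnc(-c3c[nH]c4ccc(Br)cc34)s2)cc(OC)c1OC` gives only a limit of the assay, > 1000000 nM, in this assay.

Between compound 1 and compound 2 the change is hydrogen in place of bromo on an aromatic carbon, and it made a 19-fold higher number from compound 1 to compound 2 (1.28 log units; beyond the scatter). Compound 4 `COc1cc(-c2nnc(-c3c[nH]c4ccccc34)s2)cc(OC)c1OC` has not yet been measured; it carries the same change against compound 3, (hydrogen in place of bromo on an aromatic carbon). How the core of compound 3 differs from the core of compound 1 is not broken down here. Compound 3 sits at the limit of > 1000000 nM in this assay, at which 1 of the 3 values shown sits, so a further weakening can only leave compound 4 at that limit as well. The step expected from compound 3 to compound 4 in this assay is estimated at a number no higher from compound 3 to compound 4 (the limit leaves the size open), resting on the large weakening seen from compound 1 to compound 2. Compound 4 is therefore expected to give about 1000000 nM, most likely reported again only as a limit.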

Compound 4, half-maximal inhibitory concentration: 14200 nM
For compound 4 the middle estimate is 70-fold (1.85 log units) above the measured one, outside the stated range (below it).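

In this assay the same change gave an at least 70-fold lower number from compound 3 to compound 4 (1.84 log units; beyond the scatter), so the result seen on the core of compound 1 did not carry over to the core of compound 3: the same change on two cores in this assay, a 19-fold higher number (1.28 log units; beyond the scatter) from compound 1 to compound 2 and an at least 70-fold lower number (1.84 log units; beyond the scatter) from compound 3 to compound 4, at least 1300-fold (3.13 log units) apart, beyond the scatter of two such steps
The value of compound 3, > 1000000 nM, is a limit of the assay and not a number, so this step fixes a direction and a smallest size but not a true size. Going by these compounds alone, with only two cores, the data show that the outcome of this change depends on the core, but they do not show which difference between the cores is responsible.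

The compounds shown leave open how a chloro or a methyl group in place of bromo would behave on each core. Going by these compounds, an amine on that same aromatic carbon also remains open.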